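Nitro removal on the fused ring: one measured step, one pending

The compounds below may be only part of what the source reports. "The series", "measured", "known", "first", "only" and "open" are said of these compounds alone.

Measured in a functional assay on HepG2 cells (Homo sapiens) for antiproliferative activity, read by fluorescence and resazurin assay, with a stated time of 48 h; a higher number here means a weaker inhibitor, a lower number a stronger inhibitor:
- Compound 1, `Cc1noc(NS(=O)(=O)c2ccc(NC(=O)c3cc4ccccc4oc3=O)cc2)c1C`, gives 24000 nM.
- Compound 2, `O=C(N/N=C/c1ccncc1)c1cc2cc([N+](=O)[O-])ccc2oc1=O`, gives 15800 nM.
- Compound 3, `Cc1noc(NS(=O)(=O)c2ccc(NC(=O)c3cc4cc([N+](=O)[O-])ccc4oc3=O)cc2)c1C`, gives 15000 nM.

Compound 3 and compound 1 differ in one place: hydrogen in place of nitro on an aromatic carbon. The step that goes with it is a 1.6-fold higher number from compound 3 to compound 1 (0.20 log units; within the scatter). Compound 2 sits on a different core from compound 3; the difference between the two cores is not broken down here, and the two values lie within the scatter of each other, as does the value of compound 1, so no order among the three is claimed.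

Compound 4, `O=C(N/N=C/c1ccncc1)c1cc2ccccc2oc1=O`, is not yet measured in this assay. Relative to compound 2 it carries hydrogen in place of nitro on an aromatic carbon, the same change as from compound 3 to compound 1; among these compounds the change is made twice in all, once measured and once pending.

Among the measured compounds shown here, for compound 4 the expected step is a 1.5-fold higher number from compound 2 to compound 4 (0.16 log units; within the scatter), because the one measured instance of this change gave a 1.6-fold higher number from compound 3 to compound 1 (0.20 log units; within the scatter). On that basis compound 4 is estimated at 23000 nM, with the expected span running from 10000 nM to 50000 nM.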

Compound 4, half-maximal inhibitory concentration: 17200 nM
For compound 4 the middle estimate is 1.3-fold (0.13 log units) above the measured one; low and high end bracket the measured number.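

Hydrogen in place of nitro on an aromatic carbon now has a second measured instance in this assay, with a 1.1-fold higher number from compound 2 to compound 4 (0.04 log units; within the scatter). Set beside the first instance, the steps on the two cores cannot be told apart: the same change on two cores in this assay, a 1.6-fold higher number (0.20 log units; within the scatter) from compound 3 to compound 1 and a 1.1-fold higher number (0.04 log units; within the scatter) from compound 2 to compound 4, 1.5-fold (0.17 log units) apart, within the scatter of two such steps. The change therefore carries from one core to the other without a detectable difference, but both steps lie within the scatter, so this shows neither a real effect of removing nitro on either core nor a rule for cores beyond these two.

Open, going by these compounds, is whether an amine or a carboxylic acid in place of nitro on that aromatic carbon would give a step beyond the scatter on either core. Equally open, on these data alone, is whether the step stays this small on a third core, one carrying a longer alkyl chain in place of the side chains of compound 1 and compound 4.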